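The source may report more compounds than this note shows. Statements on the series, on what has been measured and on what is new or still open speak of the compounds shown alone.

Compound 1 `CCCSc1nc(N/N=C/c2cccc(Cl)c2)c2nnn(Cc3ccccc3)c2n1` — > 64000 nM
Compound 2 `CCCSc1nc(N/N=C(\C)c2ccc(Br)cc2)c2nnn(Cc3ccccc3)c2n1` — 4670 nM

Both measured compounds share one core and differ only in the group on a nitrogen on an aromatic ring. In a functional assay on ECa-109 cells (Homo sapiens) for antiproliferative activity, read by MTT assay, with a stated time of 72 h (on this read-out higher numbers stand for weaker inhibition and lower numbers for stronger inhibition), compound 1 reaches only the limit of the measurement, > 64000 nM, so no number is known for it (the limit of > 64000 nM in this assay, at which 1 of the 2 values shown sits). Compound 2, by contrast, gives 4670 nM in this assay. Among the compounds with values here, the one measured step, an at least 13-fold lower number from compound 1 to compound 2 (1.13 log units; beyond the scatter), is large, but it changes the same region in two places at once, so it bears only loosely on the change now considered.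

Compound 3 `CCCSc1nc(N/N=C/c2ccc3ccccc3c2)c2nnn(Cc3ccccc3)c2n1` differs from compound 1 as follows: naphthalen-2-yl in place of 3-chlorophenyl on a carbon with a double bond to nitrogen. Because compound 1 shows only a limit (the limit of > 64000 nM in this assay, at which 1 of the 2 values shown sits), the size of the step to compound 3 cannot be read from the numbers; a move toward stronger inhibition is plausible but uncertain. Compound 3 is therefore expected at 20000 nM, between 4000 nM and 64000 nM, an expected step of an at least 3.2-fold lower number from compound 1 to compound 3 (0.50 log units; beyond the scatter).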

Compound 3, half-maximal inhibitory concentration: > 64000 nM
Compound 3: no number, only a limit (the forecaster's own chance of this, stated with the estimate: 40%); at least 3.2-fold (0.50 log units) between middle value and limit.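

In this assay, within the data shown here, compound 3, like compound 1, gives only a limit and not a number, so no step between the two can be read. The compounds shown leave open how strongly either inhibits, and whether naphthalen-2-yl in place of 3-chlorophenyl changes inhibition at all.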